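Furan-2-yl in place of thiophen-3-yl on the methoxy core

A few compounds are considered here, and "the series" means these few. Any claim that something is new, unique, unknown or untested is made for them only; others in the source may bear on it.

For the measured compounds named here, compound 1 `COc1ncnc2c1c(-c1ccsc1)cn2[C@@H]1O[C@H](CO)[C@@H](O)[C@H]1O` is the only member of the set with a measured number: in a functional assay on HeLa S3 cells (Homo sapiens) for antiproliferative activity, read by XTT assay, with a stated time of 72 h (a higher number here means a weaker inhibitor, a lower number a stronger inhibitor), compound 1 gives 3350 nM. Compound 2 `CNc1ncnc2c1c(-c1ccsc1)cn2[C@@H]1O[C@H](CO)[C@@H](O)[C@H]1O` reaches only the limit > 20000 nM in this assay. Compound 3 `CSc1ncnc2c1c(-c1ccsc1)cn2[C@@H]1O[C@H](CO)[C@@H](O)[C@H]1O` likewise sits at the limit > 20000 nM in this assay. The steps of an at least 5.9-fold higher number from compound 1 to compound 2 (0.77 log units; beyond the scatter) and an at least 5.9-fold higher number from compound 1 to compound 3 (0.77 log units; beyond the scatter) both concern the methoxy position and run into (the limit of > 20000 nM in this assay, at which 2 of the 3 values shown sit), and the step that the two limits leave unreadable from compound 2 to compound 3 adds nothing. Compound 4 `COc1ncnc2c1c(-c1ccco1)cn2[C@@H]1O[C@H](CO)[C@@H](O)[C@H]1O` differs from compound 1 elsewhere: furan-2-yl in place of thiophen-3-yl on an aromatic carbon. Going by the values given here, no measured step covers this change, so the expectation rests on compound 1 alone. The step of a 1.2-fold higher number from compound 1 to compound 4 (0.08 log units; within the scatter) is expected to stay within the scatter. Compound 4 is therefore estimated at 4000 nM in this assay, within 1500 nM to 12000 nM.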

Compound 4, half-maximal inhibitory concentration: 1020 nM
For compound 4 the middle estimate is 3.9-fold (0.59 log units) above the measured one; measured number outside the range, below it.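

On the methoxy core, this aromatic carbon proves sensitive to the choice of five-membered aromatic ring in this assay, with a 3.3-fold lower number from compound 1 to compound 4 (0.52 log units; beyond the scatter). For the compounds shown here, the earlier compounds varied only the methoxy position, whereas this is the first reading at this carbon, and the exchange of thiophen-3-yl for furan-2-yl is not neutral even though both groups have the same heavy-atom count. Nothing shown accounts for this difference. On these data alone, it remains open whether furan-2-yl gives a similar shift with methylamino or methylsulfanyl in place of methoxy, and how an amine or a longer chain would fare at this carbon.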